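A few compounds are considered here, and "the series" means these few. Any claim that something is new, unique, unknown or untested is made for them only; others in the source may bear on it.

Compound 1 `Oc1ccc(-c2cc(-c3cccc(F)c3)cc(-c3ccc(O)cc3)n2)cc1` gives in a functional assay on T47D cells (Homo sapiens) for inhibition (on this read-out lower numbers stand for stronger inhibition and higher numbers for weaker inhibition), a value of > 50000 nM, which is a limit of the assay.
Compound 2 `Oc1ccc(-c2cc(-c3ccc(C(F)(F)F)cc3)cc(-c3ccccc3O)n2)cc1` gives in this assay a value of > 50000 nM, again a limit.
Compound 3 `Oc1ccc(-c2cc(-c3ccc(C(F)(F)F)cc3)cc(-c3ccc(O)cc3)n2)cc1` gives in this assay a value of > 50000 nM, also a limit.

Compound 3 thus stands only at a limit, and so do the two other compounds measured (the limit of > 50000 nM in this assay, at which 3 of the 3 values shown sit). The steps a step that the two limits leave unreadable from compound 1 to compound 3 and a step that the two limits leave unreadable from compound 2 to compound 3 are consequently unreadable in size and direction. Compound 4 `Oc1ccc(-c2cc(-c3ccc(OC(F)(F)F)cc3)cc(-c3ccc(O)cc3)n2)cc1` differs from compound 3 by trifluoromethoxy in place of trifluoromethyl on an aromatic carbon. No measured step bears readably on this change, so nothing shown points to a gain beyond the scatter. Compound 4 is therefore expected to stay at the limit, the expected step being a step that the limit leaves unreadable from compound 3 to compound 4. Compound 4 is estimated at 60000 nM, with a range from 15000 nM to 300000 nM.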

Compound 4, half-maximal inhibitory concentration: 5150 nM
Compound 4: middle estimate off by 12-fold (1.07 log units), on the high side; measured number outside the range, below it.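

In this assay, trifluoromethoxy in place of trifluoromethyl on this aromatic carbon gives an at least 9.7-fold lower number from compound 3 to compound 4 (0.98 log units; beyond the scatter). Going by these compounds alone, this is the first readable step, and it shows that a change at this position can bring a compound off the limit. Its true size stays unknown, since compound 3 stands only at a limit: the limit of > 50000 nM in this assay, at which 3 of the 4 values shown sit.

The compounds shown leave open how a methoxy, an amine or a longer alkoxy chain would read at this position. On these data alone, it also remains open whether trifluoromethoxy gives a readable value alongside the 2-hydroxyphenyl of compound 2.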